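The compounds below may be only part of what the source reports. "The series", "measured", "known", "first", "only" and "open" are said of these compounds alone.

Values in a functional assay on LoVo cells (Homo sapiens) for inhibition, read by MTT assay, with a stated time of 48 h; on this read-out lower numbers stand for stronger inhibition and higher numbers for weaker inhibition

- compound 1 `COc1ccc(N(C)c2nc(C)nc3ccccc23)cc1OCCC[Se]C#N`: 921 nM
- compound 2 `COc1ccc(N(C)c2nc(C)nc3ccccc23)cc1C(=O)OCCC[Se]C#N`: 854 nM
- compound 3 `COc1ccc(N(C)c2nc(C)nc3ccccc23)cc1OCCCC[Se]C#N`: 882 nM

Compound 2 (854 nM) cannot be separated from the other two compounds on these numbers. The measured steps are a 1.1-fold lower number from compound 1 to compound 2 (0.03 log units; within the scatter) and a 1.0-fold higher number from compound 2 to compound 3 (0.01 log units; within the scatter), both within the scatter.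

The next compound to be read is compound 4 `COc1ccc(N(C)c2nc(C)nc3ccccc23)cc1C(=O)OCCCCCC[Se]C#N`, and the change from compound 2 is a group of 6 heavy atoms (4 carbon, 1 nitrogen, 1 selenium; no ring) in place of a group of 3 heavy atoms (1 carbon, 1 nitrogen, 1 selenium; no ring), on a saturated chain carbon, three bonds along the chain from an oxygen next to a carbonyl group. The closest measured precedent is a 1.0-fold lower number from compound 1 to compound 3 (0.02 log units; within the scatter), which is also a larger group in place of a smaller one on a saturated chain carbon. That step lies within the scatter, but it sits three bonds along the chain from an oxygen on an aromatic ring, not from an oxygen next to a carbonyl group. The other two steps change the group on the aromatic carbon and also stay within the scatter, so no measured change in this set has moved the number. However, none of them enlarges the group as far as this change does, and the data hold no direct test of a change of this size. The range is therefore kept wide.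

No step beyond the scatter is expected, and no direction is favoured. The estimated step is a 1.1-fold lower number from compound 2 to compound 4 (0.03 log units; within the scatter). For compound 4 the expected value is 800 nM, with an estimated range from 350 nM to 1700 nM.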

Compound 4, half-maximal inhibitory concentration: 1050 nM
The estimate for compound 4 lay 1.3-fold (0.12 log units) below the measured number; the measured number falls inside the stated range.
By their numbers in this assay, from the lowest: compounds 2, 3, 1 and 4 (each within the scatter of the next).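

In this assay, among these compounds, the step of a 1.2-fold higher number from compound 2 to compound 4 (0.09 log units; within the scatter) is the first direct test of a change this large: a group of 6 heavy atoms in place of a group of 3 heavy atoms, on a saturated chain carbon, three bonds along the chain from an oxygen next to a carbonyl group. The earlier chain step, a 1.0-fold lower number from compound 1 to compound 3 (0.02 log units; within the scatter), added less and sat three bonds along the chain from an oxygen on an aromatic ring, so the new result extends the reading to a larger group and to this second setting, and this step also lies within the scatter. Nothing available explains why the number stays within the scatter across this change.

Going by these compounds, a longer chain than the group of 6 heavy atoms remains open, so the length at which a step beyond the scatter would first appear, if one exists, cannot be told from these compounds. Also open, on these data alone, is a chain ending in an amine or a carboxylic acid instead of the selenium and nitrile end, which would test whether that end matters for the numbers.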